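The source may report more compounds than this note shows. Statements on the series, on what has been measured and on what is new or still open speak of the compounds shown alone.

Measured so far:
compound 1 `COc1ccc(NC(=O)CCc2cccc3c2B(O)OC3)cc1`: 1700 nM
compound 2 `COc1ccc(NC(=O)CCc2cccc3c2B(O)OC3)cc1OC`: > 100000 nM
compound 3 `COc1cccc(-c2cccc(NC(=O)CCc3ccccc3)c2)c1`: 40000 nM

In a functional assay on HCT-116 cells (Homo sapiens) for antiproliferative activity, read by MTT assay, with a stated time of 72 h (a higher number here means a weaker inhibitor, a lower number a stronger inhibitor), compound 1 gives 1700 nM. For compound 2 this assay reports only a limit, > 100000 nM. The step of an at least 58-fold higher number from compound 1 to compound 2 (1.76 log units; beyond the scatter) comes from a single change, (methoxy in place of hydrogen on an aromatic carbon). The size of that step is itself a lower bound, due to the limit of > 100000 nM in this assay, at which 1 of the 3 values shown sits.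

Compound 3 gives 40000 nM in this assay. How the core of compound 3 differs from the core of compound 1 is not broken down here; the two values simply stand as given.

Compound 4 `COc1cc(OC)cc(-c2cccc(NC(=O)CCc3ccccc3)c2)c1` carries the same kind of change as compound 2, (methoxy in place of hydrogen on an aromatic carbon). The surroundings differ: in compound 2 the entering methoxy is ortho to a methoxy group, in compound 4 it is meta to a methoxy group; in both it is meta to a large group.

Among the compounds with values here, the only measured instance of this change, an at least 58-fold higher number from compound 1 to compound 2 (1.76 log units; beyond the scatter), is large, so a weakening of similar direction is expected here. Compound 4 is expected to give about 120000 nM, plausibly between 40000 nM and 400000 nM. That expectation corresponds to a step of a 3.0-fold higher number from compound 3 to compound 4 (0.48 log units; beyond the scatter), and a limit rather than a number is quite possible.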

Compound 4, half-maximal inhibitory concentration: > 100000 nM
Compound 4 was reported as a limit (the forecaster's own chance of this, stated with the estimate: 60%); the middle value is on the limit's open side.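

In this assay compound 4 gives > 100000 nM, which is a limit of the assay and not a number. Methoxy in place of hydrogen on an aromatic carbon raises the number on this second core as well, with an at least 2.5-fold higher number from compound 3 to compound 4 (0.39 log units; beyond the scatter), so the direction of the change is the same on the two cores shown: the same change on two cores in this assay, an at least 58-fold higher number (1.76 log units; beyond the scatter) from compound 1 to compound 2 and an at least 2.5-fold higher number (0.39 log units; beyond the scatter) from compound 3 to compound 4; the limit leaves it open whether they differ The size of the effect cannot be compared or carried from one core to the other, and neither step gives a true magnitude, due to the assay limit: the limit of > 100000 nM in this assay, at which 2 of the 4 values shown sit.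

The compounds shown leave open whether a hydroxyl, an amine or a carboxylic acid in place of the entering methoxy would move the number in the same direction on either core. They also leave open whether a longer chain in place of the chain that carries the amide would alter the response of either core to this change.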